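Aryl swap on the urea nitrogen: compound 1 to compound 3

The compounds below may be only part of what the source reports. "The series", "measured", "known", "first", "only" and "open" are said of these compounds alone.

Going by the values given here, compound 1 `COc1ccc(CN(C(=O)Nc2ccc(F)c(Cl)c2)n2cnnc2)cc1OC` gives 21000 nM in a functional assay on A549 cells (Homo sapiens) for cytotoxicity, read by MTT assay, with a stated time of 48 h (a lower number here means a stronger inhibitor, a higher number a weaker inhibitor), the highest of the two numbers measured so far. Compound 2 `COc1ccc(OC)c(CN(C(=O)Nc2ccc(C)cc2)n2cnnc2)c1` gives 17400 nM in this assay, which lies within the scatter of the number for compound 1. Compound 3 `COc1ccc(CN(C(=O)Nc2ccc(C)cc2)n2cnnc2)cc1OC` is compound 1 with 4-methylphenyl in place of 3-chloro-4-fluorophenyl on an amide-type nitrogen. Among the compounds with values here, no measured pair isolates this change. The step from compound 1 to compound 3 is expected to be a 1.1-fold lower number from compound 1 to compound 3 (0.04 log units; within the scatter), nothing beyond the scatter, because compound 2 with the same 4-methylphenyl group on a differently substituted core gives 17400 nM. Compound 3 is therefore estimated at 19000 nM, with a range from 8000 nM to 45000 nM.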

Compound 3, half-maximal inhibitory concentration: 22200 nM
Compound 3: middle estimate off by 1.2-fold (0.07 log units), on the low side; low and high end bracket the measured number.
By their numbers in this assay, from the lowest: compounds 2, 1 and 3 (each within the scatter of the next).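

Going by these compounds alone, on the amide-type nitrogen, 4-methylphenyl in place of 3-chloro-4-fluorophenyl gives a 1.1-fold higher number from compound 1 to compound 3 (0.02 log units; within the scatter) in this assay and is the only measured step that isolates this position. On the core of compound 1, this assay does not tell the two aryl groups apart. No available evidence explains this result.

Open, from the compounds shown here alone, is whether cyclohexyl on the amide-type nitrogen, or a phenyl carrying a carboxylic acid or an amine, would give a number beyond the scatter of these values.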